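The compounds below may be only part of what the source reports. "The series", "measured", "known", "first", "only" and "open" are said of these compounds alone.

Three related compounds have been tested in an ADME assay on Vero cells (Chlorocebus sabaeus) for cytotoxicity, read by resazurin assay, with a stated time of 72 h; on this read-out lower numbers stand for stronger inhibition and higher numbers for weaker inhibition. Compound 1 `O=C(CCN1CCN(c2ccc(F)cc2)CC1)c1ccc(F)c(Cl)c1` gives 185000 nM, compound 2 `O=C(CCN1CCN(c2ccc(C(F)(F)F)cc2)CC1)c1ccc(F)c(Cl)c1` gives 74500 nM, and compound 3 `O=C(CCN1CCN(c2ccc(F)cc2)CC1)c1ccc(Cl)c(F)c1` gives 105000 nM. Compound 4 `O=C(CCN1CCN(c2ccc(C(F)(F)F)cc2)CC1)c1ccc(Cl)c(F)c1` awaits measurement. Going from compound 1 to compound 2, the change is trifluoromethyl in place of fluoro on an aromatic carbon, and it made a 2.5-fold lower number from compound 1 to compound 2 (0.40 log units; beyond the scatter). Compound 3 differs from compound 1 in its core, (4-chloro-3-fluorophenyl in place of 3-chloro-4-fluorophenyl on a carbonyl carbon), with a 1.8-fold lower number from compound 1 to compound 3 (0.25 log units; within the scatter). Compound 4 carries the same change relative to compound 3, (trifluoromethyl in place of fluoro on an aromatic carbon), and the surroundings of the place are described in the same words, so this is the same kind of change on the core of compound 3. Among the compounds with values here, the earlier step suggests a step of similar size here, because a 2.5-fold lower number from compound 1 to compound 2 (0.40 log units; beyond the scatter) is the only guide. The step expected is a 2.5-fold lower number from compound 3 to compound 4 (0.40 log units; beyond the scatter). Compound 4 is therefore estimated at 42000 nM, likely between 20000 nM and 90000 nM.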

Compound 4, half-maximal inhibitory concentration: 74300 nM
Compound 4: middle estimate off by 1.8-fold (0.25 log units), on the low side; the measured number falls inside the stated range.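

In this assay, trifluoromethyl in place of fluoro gave a 1.4-fold lower number from compound 3 to compound 4 (0.15 log units; within the scatter), and this step does not clearly differ from the earlier one: the same change on two cores in this assay, a 2.5-fold lower number (0.40 log units; beyond the scatter) from compound 1 to compound 2 and a 1.4-fold lower number (0.15 log units; within the scatter) from compound 3 to compound 4, 1.8-fold (0.24 log units) apart, within the scatter of two such steps. Likewise, 4-chloro-3-fluorophenyl in place of 3-chloro-4-fluorophenyl gave a 1.0-fold lower number from compound 2 to compound 4 (0.00 log units; within the scatter), which also agrees with its earlier counterpart: the same change on two cores in this assay, a 1.8-fold lower number (0.25 log units; within the scatter) from compound 1 to compound 3 and a 1.0-fold lower number (0.00 log units; within the scatter) from compound 2 to compound 4, 1.8-fold (0.24 log units) apart, within the scatter of two such steps. Each change therefore carried across these two cores without a detectable difference, but two pairs with small steps, three of the four within the scatter, do not show that either step would hold on another core.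

On these data alone, only fluoro and trifluoromethyl appear on that aromatic carbon, so a nitrile or a methoxy group there remains open. As far as these compounds go, a longer chain leading to the carbonyl also remains open.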